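The source may report more compounds than this note shows. Statements on the series, on what has been measured and on what is new or still open speak of the compounds shown alone.

Compound 1 `COc1ccc(C(c2ccc(OC)cc2)C2CCN(CCCOc3ccc(C(C)=O)cc3OC)CC2)cc1`, compound 2 `COc1cc(C(C)=O)ccc1OCCCN1CCC(C(C(N)=O)(c2ccc(F)cc2)c2ccc(F)cc2)CC1` and compound 3 `CC(=O)c1ccc(OCCCN2CCC(C(c3ccc(F)cc3)c3ccc(F)cc3)CC2)cc1` were all tested in a functional assay (aorta) with Oryctolagus cuniculus as the target; on this read-out lower numbers stand for tighter binding and higher numbers for weaker binding. In this assay compound 1 gives 10 nM, compound 2 gives 25.1 nM, and compound 3 gives 2.51 nM. Compound 3 therefore has the lowest number of the three, and its distance from each of the other two lies beyond the usual scatter of repeated measurements, so within this small set it is the tightest binder.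

The next compound, compound 4 `CN(CCCN1CCC(C(c2ccc(F)cc2)c2ccc(F)cc2)CC1)c1ccccc1`, has not yet been measured in this assay. It differs from compound 3 in a single place: methyl(phenyl)amino in place of 4-acetylphenoxy on a saturated chain carbon, three bonds along the chain from an amine nitrogen in a ring. Going by the values given here, no pair of measured compounds differs by exactly this change, so there is no measured step to lean on. Among the compounds with values here, the only guide is that all three measured compounds keep the 4-acetylphenoxy group, or a close relative of it, and all three bind tightly, while compound 4 gives that group up entirely. A moderate loss of binding beyond the scatter is therefore expected, with the step of a 3.2-fold higher number from compound 3 to compound 4 (0.50 log units; beyond the scatter) in the direction of weaker binding. Compound 4 is estimated at 8 nM, within a range of 2 nM to 40 nM.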

Compound 4, dissociation constant: 2 nM
Estimate against measurement, compound 4: 4.0-fold (0.60 log units) above; the measured number falls inside the stated range.
By their numbers in this assay, from the lowest: compounds 4 and 3 (each within the scatter of the next); then compound 1; then compound 2.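

In this assay, replacing the 4-acetylphenoxy group with methyl(phenyl)amino gives a 1.3-fold lower number from compound 3 to compound 4 (0.10 log units; within the scatter), so the two compounds cannot be told apart. Going by these compounds alone, all the earlier compounds carried 4-acetylphenoxy or a close relative of it, which left open whether binding depended on that group; compound 4 shows that, at this saturated chain carbon, three bonds along the chain from the ring amine nitrogen, tight binding survives without the acetyl group or the oxygen that links the group to the chain. Both groups still hold a six-membered aromatic ring of carbon only, and nothing shown here explains why the swap is tolerated.

Going by these compounds, what remains open is whether that aromatic ring is needed at all, which a small group such as a dimethylamine or a carboxylic acid in the same place could test. A longer chain between the ring amine nitrogen and the methyl(phenyl)amino group, or the same swap on the core of compound 1 or compound 2, could also show how far this tolerance extends.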